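Aryl swap on the ring amine nitrogen: compound 3

The source may hold more compounds than are shown below. What is called first, only, known or untested is meant among the compounds shown, and "the series" means these compounds.

Measured so far in a functional assay on CHO cells with adenosine receptor A1 (Homo sapiens) as the target, read by cAMP accumulation and immunoassay, with a stated time of 6 min, tested at 10 uM; on this read-out higher numbers stand for a weaker effect at the one concentration tested and lower numbers for a stronger effect:
Compound 1 `Nc1scc(CN2CCN(c3cccc(Cl)c3Cl)CC2)c1C(=O)c1ccc(Cl)cc1` gives -77%.
Compound 2 `Nc1scc(CN2CCN(c3cccnc3)CC2)c1C(=O)c1ccc(Cl)cc1` gives -23%.

Compound 2 has the highest number of the two; its nearest neighbour is compound 1, and the step of a number 54 percentage points higher from compound 1 to compound 2 (beyond the scatter) lies beyond the scatter. Compound 3 `Nc1scc(CN2CCN(c3cc(F)cc(F)c3)CC2)c1C(=O)c1ccc(Cl)cc1` is not yet measured. It differs from compound 2 in one place: 3,5-difluorophenyl in place of pyridin-3-yl on an amine nitrogen in a ring. Among the compounds with values here, only one measured step bears on this change, a number 54 percentage points higher from compound 1 to compound 2 (beyond the scatter), in which a dihalogenated phenyl on the same ring nitrogen gave way to pyridin-3-yl and the number rose by a large amount. The change to compound 3 runs the other way, pyridin-3-yl leaving and a dihalogenated phenyl entering, though with fluorine rather than chlorine, so the full size of that earlier step need not return. A step downward beyond the scatter is therefore expected in this assay, estimated as a number 32 percentage points lower from compound 2 to compound 3 (beyond the scatter). Compound 3 is expected to give about -55%, with a range from -85% to -20%.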

Compound 3, a percentage reported as activity, at one concentration (the size of the read-out at that concentration, not a potency): -79%
The estimate for compound 3 lay 24 percentage points above the measured number; low and high end bracket the measured number.
By their numbers in this assay, from the lowest: compounds 3 and 1 (each within the scatter of the next); then compound 2.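

With 3,5-difluorophenyl on the ring nitrogen in this assay, the change from pyridin-3-yl gives a number 56 percentage points lower from compound 2 to compound 3 (beyond the scatter), a large step that runs opposite in direction to a number 54 percentage points higher from compound 1 to compound 2 (beyond the scatter) and shows that this position responds in both directions. The exchange of one dihalogenated phenyl for the other gives a number 2 percentage points lower from compound 1 to compound 3 (within the scatter), so the read-out does not separate 3,5-difluorophenyl from 2,3-dichlorophenyl, even though the two differ in halogen and in substitution pattern. Among these three compounds the division lies between pyridin-3-yl and the two dihalogenated phenyl groups, with nothing available to explain it.

From the compounds shown here alone, whether the gap follows the ring nitrogen of pyridin-3-yl or the halogens on the phenyl ring remains open, and an unsubstituted phenyl or a chloropyridinyl group on the same nitrogen would separate the two. Equally open, going by these compounds, is whether a phenyl bearing methoxy, nitrile or an amine would stay with compound 1 and compound 3 or fall with compound 2.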